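The source may report more compounds than this note shows. Statements on the series, on what has been measured and on what is new or still open speak of the compounds shown alone.

Of the compounds shown here, three have been measured in a functional assay on cells (Mus musculus) for cytotoxicity, read by MTT assay, with a stated time of 24 h; on this read-out lower numbers stand for an effect already at smaller amounts and higher numbers for an effect only at larger amounts of compound. Compound 1 `CC(C)=CCc1cc(/C=C/C(=O)O)cc2c1OC(C)(C)C(O)C2` gives 77.1 ug/mL. Compound 2 `C=C1CC[C@@H]2[C@](C)(CCC[C@]2(C)C(=O)O)[C@H]1CC/C(C)=C/CO` gives 63.5 ug/mL, and compound 3 `C=C1CC[C@@H]2[C@](C)(CCC[C@]2(C)C(=O)O)[C@H]1CC/C(C)=C/COC(C)=O` gives 73.3 ug/mL. Going by the values given here, the one step that can be isolated, a 1.2-fold higher number from compound 2 to compound 3 (0.06 log units; within the scatter), changes almost nothing. Compound 3 gives the second highest of the three numbers, with compound 1 nearest and compound 2 furthest, though all three lie within the usual scatter of one another. Compound 4 `C=C1CC[C@@H]2[C@](C)(CCC[C@]2(C)C(=O)O)[C@H]1CC/C(C)=C/C(=O)O` differs from compound 3 by carboxy in place of acetoxymethyl on a double-bonded chain carbon bound to a double-bonded chain carbon. Among the compounds with values here, no measured step covers this exchange. Within the data shown here, the only known step, from compound 2 to compound 3, touched the same end of the chain and stayed within the scatter. For compound 4 a step of similar small size is expected, a 1.0-fold lower number from compound 3 to compound 4 (0.02 log units; within the scatter), in no clear direction. Compound 4 is therefore estimated at 70 ug/mL, expected to fall between 35 ug/mL and 140 ug/mL.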

Compound 4, concentration for half-maximal effect: 95.9 ug/mL
Compound 4: the middle estimate sits 1.4-fold (0.14 log units) below what was measured; low and high end bracket the measured number.
By their numbers in this assay, from the lowest: compounds 2, 3, 1 and 4 (each within the scatter of the next).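

Carboxy in place of acetoxymethyl on a double-bonded chain carbon bound to a double-bonded chain carbon gives a 1.3-fold higher number from compound 3 to compound 4 (0.12 log units; within the scatter) in this assay, and carboxy in place of hydroxymethyl at the same place gives a 1.5-fold higher number from compound 2 to compound 4 (0.18 log units; within the scatter). Going by these compounds alone, this place has now carried three different groups, hydroxymethyl, acetoxymethyl and carboxy, and no step among them leaves the scatter. No measurement shown offers a reason for this. From the compounds shown here alone, what an amine or a longer chain at this place would give remains open.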